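Swapping the basic side chain on a shared core

This account rests on a few compounds, and the source may have more. Where it says the series, first, only, none or still open, it means among the compounds named here.

Of the compounds shown here, three built on one shared core have been measured in a functional assay on A-375 cells (Homo sapiens) for cytotoxicity, read by MTT assay, with a stated time of 72 h; a higher number here means a weaker inhibitor, a lower number a stronger inhibitor. Going by the values given here, compound 1 `O=C1c2c[n+]([O-])c3ccccc3c2C(=O)c2c1c1ccccc1n2Cc1cn([C@H]2O[C@H](CO)[C@@H](O)[C@H]2O)nn1` gives 340 nM, while compound 2 `O=C1c2c[n+]([O-])c3ccccc3c2C(=O)c2c1c1ccccc1n2Cc1cn([C@@H]2C[C@H](O)[C@@H](CO)O2)nn1` gives 20 nM; the step of a 17-fold lower number from compound 1 to compound 2 (1.23 log units; beyond the scatter) is the only one-point change among the measured compounds. Compound 3 `CN1CCN(CCCCn2c3c(c4ccccc42)C(=O)c2c[n+]([O-])c4ccccc4c2C3=O)CC1` carries a side chain on the aromatic nitrogen instead of a sugar-like ring and gives 30 nM, which stands second highest of the three numbers: its value and that of compound 2 sit within the usual scatter of each other, and compound 1 stands clearly higher.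

Compound 4 `O=C1c2c[n+]([O-])c3ccccc3c2C(=O)c2c1c1ccccc1n2CCCN1CCC(O)CC1` is the unmeasured member. It differs from compound 3 as follows: 4-hydroxypiperidin-1-yl in place of (4-methylpiperazin-1-yl)methyl on a saturated chain carbon, three bonds along the chain from an aromatic nitrogen. Among the compounds with values here, no measured step touches this kind of change. The step from compound 1 to compound 2 concerns a hydroxy on a saturated ring carbon of a sugar-like group, not a basic side chain, so it gives no direct guide here. With nothing comparable to lean on, the expectation is a step of a 1.5-fold higher number from compound 3 to compound 4 (0.18 log units; within the scatter), that is, no change beyond the scatter in either direction. Compound 4 is therefore expected to give about 45 nM, most likely between 15 nM and 150 nM.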

Compound 4, half-maximal inhibitory concentration: 240 nM
For compound 4 the middle estimate is 5.3-fold (0.73 log units) below the measured one; the whole stated range lies below it.
By their numbers in this assay, from the lowest: compounds 2 and 3 (each within the scatter of the next); then compounds 4 and 1 (each within the scatter of the next).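

In this assay, the end of the side chain on the aromatic nitrogen turns out to matter: 4-hydroxypiperidin-1-yl in place of (4-methylpiperazin-1-yl)methyl, on a saturated chain carbon three bonds along the chain from an aromatic nitrogen, gives an 8.0-fold higher number from compound 3 to compound 4 (0.90 log units; beyond the scatter). Going by these compounds alone, the earlier compounds could not show this, as their only one-place step concerned a hydroxy on a sugar-like ring, not this side chain. The same difference also reads as 4-(4-methylpiperazin-1-yl)butyl to 3-(4-hydroxypiperidin-1-yl)propyl, so the ring at the chain end and the length of the chain change together, and this single step cannot separate the two.

No measurement shown here accounts for the size of this step. Still open, on these data alone, is how 4-methylpiperazin-1-yl on a propyl chain or 4-hydroxypiperidin-1-yl on a butyl chain would compare, and where a morpholine or a dimethylamine at the end of the chain would fall.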